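This account rests on a few compounds, and the source may have more. Where it says the series, first, only, none or still open, it means among the compounds named here.

For the measured compounds named here, compound 2 `COc1ccc([C@@H]2CC(=O)c3c(O)cc(OCc4cn(Cc5ccccc5)nn4)cc3O2)cc1O` is one of three compounds measured in a functional assay on RAW264.7 cells (Mus musculus) for inhibition, read by Griess assay, with stated times of 2 h and 24 h (a higher number here means a weaker inhibitor, a lower number a stronger inhibitor), where compound 2 gives 11000 nM. Compound 1 `COc1ccc([C@@H]2CC(=O)c3c(O)cc(OCc4cn(Cc5ccc(C(F)(F)F)cc5)nn4)cc3O2)cc1O` gives 17700 nM, and compound 3 `CCCn1cc(COc2cc(O)c3c(c2)O[C@H](c2ccc(OC)c(O)c2)C/C3=N\O)nn1`, built on a different core, gives 2340 nM; compound 2 thus stands second highest of the three, nearest to compound 1 and furthest from compound 3. Compound 4 `COc1ccc([C@@H]2CC(=O)c3c(O)cc(OCc4cn(Cc5ccccc5C#N)nn4)cc3O2)cc1O` differs from compound 2 by cyano in place of hydrogen on an aromatic carbon. Going by the values given here, the only measured step on that benzyl group, a 1.6-fold lower number from compound 1 to compound 2 (0.21 log units; within the scatter), lies within the scatter, so a change there has so far moved the number little. A small step is therefore expected, a 1.1-fold lower number from compound 2 to compound 4 (0.04 log units; within the scatter), with no sure direction. Compound 4 is estimated at 10000 nM, between 4000 nM and 25000 nM.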

Compound 4, half-maximal inhibitory concentration: 14600 nM
The estimate for compound 4 lay 1.5-fold (0.16 log units) below the measured number; measured number inside the range.
By their numbers in this assay, from the lowest: compound 3; then compounds 2, 4 and 1 (each within the scatter of the next).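

In this assay, the change from benzyl to 2-cyanobenzyl gives a 1.3-fold higher number from compound 2 to compound 4 (0.12 log units; within the scatter), so a substituent ortho to a large group also leaves the number within the scatter. The swap of 4-(trifluoromethyl)phenyl for 2-cyanophenyl gives a 1.2-fold lower number from compound 1 to compound 4 (0.08 log units; within the scatter), so these two substituted rings cannot be told apart here. Nothing measured here explains why these numbers stay so close. Still open, going by these compounds, is whether an amine or a carboxylic acid on this ring would move the number beyond the scatter.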